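The compounds below may be only part of what the source reports. "The series", "measured", "known", "first", "only" and "open" are said of these compounds alone.

Compounds that share one core and differ in the group on the sulfur have been tested in a functional assay on HT-29 cells (Homo sapiens) for inhibition, read by MTT assay, with a stated time of 48 h; on this read-out higher numbers stand for weaker inhibition and lower numbers for stronger inhibition. Compound 1 `CCSc1nnc(-c2cc(OC)c(OC)c(OC)c2)n1-c1ccc(N(C)C)cc1` gives > 60000 nM, which is a limit of the assay and not a number. Compound 2 `COc1cc(-c2nnc(SCc3ccccc3)n2-c2ccc(N(C)C)cc2)cc(OC)c1OC` gives > 60000 nM, which is also a limit. For the measured compounds named here, compound 3 `COc1cc(-c2nnc(SCc3ccc(C)cc3)n2-c2ccc(N(C)C)cc2)cc(OC)c1OC` gives 27500 nM, the only true number so far, and the rest of the set sits at the limit of > 60000 nM in this assay, at which 2 of the 3 values shown sit.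

Compound 4 `COc1cc(-c2nnc(SCC(=O)c3ccccc3)n2-c2ccc(N(C)C)cc2)cc(OC)c1OC` changes the sulfur side chain of compound 3: benzoyl in place of 4-methylphenyl on a saturated chain carbon bound to a sulfur. In words, benzoyl stands in place of 4-methylphenyl on a saturated chain carbon bound to a sulfur, so the ring methyl is lost and a carbonyl enters.

Going by the values given here, three measured steps bear on this. Among the compounds with values here, the first is a step that the two limits leave unreadable from compound 1 to compound 2. The second is an at least 2.1-fold lower number from compound 1 to compound 3 (0.33 log units; beyond the scatter), and the third is an at least 2.1-fold lower number from compound 2 to compound 3 (0.33 log units; beyond the scatter). That third step matters most, since compound 4 lacks the same ring methyl, which points towards a higher number. Within the data shown here, no tested compound carries a carbonyl in this chain, so its contribution remains open.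

The expected change is therefore a 1.1-fold higher number from compound 3 to compound 4 (0.04 log units; within the scatter), which means no expected step beyond the scatter, although a limit result is quite possible. For compound 4 the estimate is 30000 nM, with an expected range from 8000 nM to 60000 nM.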

Compound 4, half-maximal inhibitory concentration: 45200 nM
Beside the measured number, compound 4's estimate is 1.5-fold (0.18 log units) below it, within the range that was stated.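

For the compounds shown here, a carbonyl now enters this chain for the first time in the set, and benzoyl in place of 4-methylphenyl gives a 1.6-fold higher number from compound 3 to compound 4 (0.22 log units; within the scatter), so in this assay these two groups cannot be told apart. Benzoyl in place of phenyl gives an at least 1.3-fold lower number from compound 2 to compound 4 (0.12 log units; that floor lies within the scatter), and benzoyl in place of methyl gives an at least 1.3-fold lower number from compound 1 to compound 4 (0.12 log units; that floor lies within the scatter); both are only floors, and neither floor by itself separates the two compounds it links. Compound 4 is therefore the second compound with a true number, which shows that a side chain other than 4-methylbenzyl can also give a number in this assay, while the remaining compounds stay at a limit: the limit of > 60000 nM in this assay, at which 2 of the 4 values shown sit.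

The compounds shown cannot separate the effect of the entering carbonyl from that of the lost ring methyl, and a 4-methylbenzoyl group on the same chain carbon would set the two apart. Also open, going by these compounds, is how this assay would read for a side chain ending in an amine or a carboxylic acid in place of the aromatic ring.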